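This account rests on a few compounds, and the source may have more. Where it says the series, first, only, none or still open, it means among the compounds named here.

The series shares the core of compound 1 `CCC1(Cc2ccccc2)OS(=O)(=O)C=C1OC` and varies the group on the oxygen on an unsaturated carbon. In an ADME assay on HEL cells (Homo sapiens) for cytotoxicity, with a stated time of 3 days (a higher number here means that more compound is tolerated, a lower number that less compound is tolerated), compound 1 gives > 200000 nM, which is a limit of the assay rather than a number. Compound 2 `CCC1(Cc2ccccc2)OS(=O)(=O)C=C1OS(=O)(=O)c1ccc(C)cc1` gives 109000 nM in this assay. Compound 3 `CCC1(Cc2ccccc2)OS(=O)(=O)C=C1OC(c1ccccc1)c1ccccc1` gives > 200000 nM, again a limit of the assay and not a number. Two of the three values thus sit at the limit of > 200000 nM in this assay, at which 2 of the 3 values shown sit, so compound 1 can be placed no more exactly than at that limit. Compound 4 `CCC1(Cc2ccccc2)OS(=O)(=O)C=C1OCCc1ccccc1` has not yet been measured in this assay. Compound 4 differs from compound 1 by benzyl in place of hydrogen on a saturated chain carbon bound to an oxygen on an unsaturated carbon. Within the data shown here, no step between two measured compounds has been counted, so the values shown give no measured step to go by. The step of a number no higher from compound 1 to compound 4 (the limit leaves the size open) is expected to be none beyond the scatter, most likely ending once more at the limit. Compound 4 is therefore expected to give 200000 nM, with a range from 100000 nM to 400000 nM.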

Compound 4, half-maximal cytotoxic concentration: 48000 nM
Beside the measured number, compound 4's estimate is 4.2-fold (0.62 log units) above it, and the stated range ends above it.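

In this assay, among these compounds, benzyl in place of hydrogen on a saturated chain carbon bound to an oxygen on an unsaturated carbon gives an at least 4.1-fold lower number from compound 1 to compound 4 (0.61 log units; beyond the scatter), the first measured step at this position and evidence that this change can move the read-out. Compound 3 also carries aromatic rings on this oxygen and gives > 200000 nM, which is a limit of the assay, so an aromatic ring in this group does not always give a number rather than a limit. The size of the step is open on one side, since compound 1 stands at a limit: the limit of > 200000 nM in this assay, at which 2 of the 4 values shown sit.

Whether the lower number belongs to phenethyl alone or to chains of this kind in general remains open, as this is the only step available. A phenylpropyl group, or an amine at the end of the chain, would bear on that question.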